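The source may report more compounds than this note shows. Statements on the series, on what has been measured and on what is new or still open speak of the compounds shown alone.

Measured compounds: compound 1 `COc1ccc(C(=O)Nc2nn(-c3ccccc3)c(=O)c3ccccc23)cc1`, compound 2 `COc1ccccc1CNC(=O)Nc1nn(-c2ccccc2)c(=O)c2ccccc12`, compound 3 `CC(=O)Nc1nn(-c2ccccc2)c(=O)c2ccccc12`.

In an assay on CHO cells for displacement of a labelled ligand from adenosine receptor A1 (Homo sapiens), tested at 10 uM (a lower number here means less inhibition, a higher number more inhibition at the concentration tested (going by the name of the read-out)), compound 1 gives 0%, compound 2 gives 28%, and compound 3 gives 52%, the highest of the three. Compound 4 `Cc1ccc(NC(=O)Nc2nn(-c3ccccc3)c(=O)c3ccccc23)cc1` differs from compound 3 by (4-methylphenyl)amino in place of methyl on a carbonyl carbon. Within the data shown here, two measured steps bear on this: a number 24 percentage points higher from compound 2 to compound 3 (beyond the scatter) and a number 52 percentage points higher from compound 1 to compound 3 (beyond the scatter), both showing that the methyl on the carbonyl carbon outscored the larger amino or aryl groups. Reversing that direction, compound 4 is expected to lose ground, with an estimated a number 30 percentage points lower from compound 3 to compound 4 (beyond the scatter). The estimate for compound 4 in this assay is therefore 22%, within a range from 2% to 45%.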

Compound 4, a percentage reported as inhibition, at one concentration (the size of the read-out at that concentration, not a potency): 29%
The estimate for compound 4 lay 7 percentage points below the measured number; the measured number falls inside the stated range.
By their numbers in this assay, from the lowest: compound 1; then compounds 2 and 4 (each within the scatter of the next); then compound 3.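

In this assay, (4-methylphenyl)amino on the carbonyl carbon gives a number 23 percentage points lower from compound 3 to compound 4 (beyond the scatter), so the methyl also outscores this third, aryl-bearing replacement. On the amide-type nitrogen, 4-methylphenyl in place of 2-methoxybenzyl gives a number 1 percentage points higher from compound 2 to compound 4 (within the scatter), so this change makes no discernible difference, while (4-methylphenyl)amino in place of 4-methoxyphenyl gives a number 29 percentage points higher from compound 1 to compound 4 (beyond the scatter). Nothing available explains these steps.

From the compounds shown here alone, what an ethyl or a plain amino group on the carbonyl carbon would give remains open, as does the effect of a carboxylic acid in place of the methyl on the 4-methylphenyl ring.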